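A few compounds are considered here, and "the series" means these few. Any claim that something is new, unique, unknown or untested is made for them only; others in the source may bear on it.

Compound 1 `O=C(Nc1cc(-c2ccccc2)nn1-c1ccccc1)c1cccc([N+](=O)[O-])c1`: 2220 nM
Compound 2 `O=C(Nc1cc(-c2ccccc2)nn1-c1ccccc1)c1cc([N+](=O)[O-])cc([N+](=O)[O-])c1`: "not determined" (no result reported)
Compound 3 `N#Cc1cccc(-n2nc(-c3ccccc3)cc2NC(=O)c2ccccc2)c1`: > 10000 nM

Among the compounds with values here, in an assay on HEK293 cells for displacement of a labelled ligand from metabotropic glutamate receptor 5 (Rattus norvegicus) (a lower number here means a stronger inhibitor, a higher number a weaker inhibitor), compound 1 gives 2220 nM, and this is the only plain number among the three entries. Compound 2 has no result in this assay. Compound 3 reaches only (the limit of > 10000 nM in this assay, at which 1 of the 3 values shown sits), a limit of this assay and not a number. Compound 1 therefore stands alone as the sole anchor, with nothing to rank it against.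

The next compound, compound 4 `O=C(Nc1cc(-c2ccccc2)nn1-c1ccccc1)C1CCCC1`, differs from compound 1 in one place: cyclopentyl in place of 3-nitrophenyl on a carbonyl carbon. Within the data shown here, no step between measured compounds is available to calibrate such an exchange in this assay. Swapping an aromatic nitrophenyl for a small saturated cyclopentyl at the amide carbonyl is a change of a different kind from those seen here, and the expectation is a weakening of binding somewhat beyond the usual scatter rather than a gain. Compound 4 is expected to give about 5500 nM, with a plausible range from 1500 nM to 20000 nM. The step so estimated is a 2.5-fold higher number from compound 1 to compound 4 (0.39 log units; beyond the scatter).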

Compound 4, inhibition constant: 11600 nM
For compound 4 the middle estimate is 2.1-fold (0.32 log units) below the measured one; the range from low to high includes it.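

Cyclopentyl in place of 3-nitrophenyl on a carbonyl carbon gives, in this assay, a 5.2-fold higher number from compound 1 to compound 4 (0.72 log units; beyond the scatter), the first measured sign that the number responds to the group at this position. The step does not separate the parts of the exchange, as 3-nitrophenyl differs from cyclopentyl in its aromatic ring, its heavy atoms and its hydrogen-bond acceptors alike. Compound 3 differs from both in more than one place, and its entry is a limit of the assay and not a number: the limit of > 10000 nM in this assay, at which 1 of the 4 values shown sits.

The compounds shown leave open which of those differences accounts for the step, and whether any group at this position would bring the number below that of compound 1. An amine, a carboxylic acid or a longer chain on the carbonyl carbon lies outside what they can answer.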